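Amine substituent variation: estimate for methoxycarbonylethyl analogue

The source may report more compounds than this note shows. Statements on the series, on what has been measured and on what is new or still open speak of the compounds shown alone.

Among the measured compounds shown here, compound 3 `Cc1cn([C@@H]2O[C@H](CO[Si](C)(C)C(C)(C)C)[C@@]3(OS(=O)(=O)C=C3NC(N)=O)[C@H]2O[Si](C)(C)C(C)(C)C)c(=O)n(C)c1=O` gives 11000 nM in a functional assay on HEL cells (Homo sapiens) (on this read-out lower numbers stand for higher toxicity in this test and higher numbers for lower toxicity in this test), the second highest of the three numbers measured so far. Compound 1 `Cc1cn([C@@H]2O[C@H](CO[Si](C)(C)C(C)(C)C)[C@@]3(OS(=O)(=O)C=C3NC(=O)c3ccccc3)[C@H]2O[Si](C)(C)C(C)(C)C)c(=O)n(C)c1=O` gives 9700 nM and compound 2 `Cc1cn([C@@H]2O[C@H](CO[Si](C)(C)C(C)(C)C)[C@@]3(OS(=O)(=O)C=C3NCCC(N)=O)[C@H]2O[Si](C)(C)C(C)(C)C)c(=O)n(C)c1=O` gives 14800 nM in this assay. All three sit within the scatter of one another: a 1.5-fold higher number from compound 1 to compound 2 (0.18 log units; within the scatter), a 1.1-fold higher number from compound 1 to compound 3 (0.05 log units; within the scatter) and a 1.3-fold lower number from compound 2 to compound 3 (0.13 log units; within the scatter). Compound 4 `COC(=O)CCNC1=CS(=O)(=O)O[C@@]12[C@@H](CO[Si](C)(C)C(C)(C)C)O[C@@H](n1cc(C)c(=O)n(C)c1=O)[C@@H]2O[Si](C)(C)C(C)(C)C` differs from compound 3 by 2-(methoxycarbonyl)ethyl in place of carbamoyl on an amine nitrogen. The closest measured comparison is the exchange of carbamoyl for 2-carbamoylethyl on the same nitrogen, which stayed within the scatter, as did both benzoyl exchanges; no substituent on the amine nitrogen has yet moved the number beyond it. The step expected is therefore a 1.1-fold higher number from compound 3 to compound 4 (0.04 log units; within the scatter), nothing beyond the scatter. Compound 4 is estimated at 12000 nM, with a range of 6000 nM to 25000 nM.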

Compound 4, half-maximal cytotoxic concentration: 94000 nM
For compound 4 the middle estimate is 7.8-fold (0.89 log units) below the measured one, and the stated range ends below it.
By their numbers in this assay, from the lowest: compounds 1, 3 and 2 (each within the scatter of the next); then compound 4.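

On this amine nitrogen the number can move after all in this assay: 2-(methoxycarbonyl)ethyl gives steps beyond the scatter against carbamoyl (an 8.5-fold higher number from compound 3 to compound 4 (0.93 log units; beyond the scatter)) and against benzoyl (a 9.7-fold higher number from compound 1 to compound 4 (0.99 log units; beyond the scatter)). Methoxy in place of amino on a carbonyl carbon is enough on its own (a 6.4-fold higher number from compound 2 to compound 4 (0.80 log units; beyond the scatter)), so the end of the chain counts here, not just the chain. Nothing available bears on the reason for this shift.

Open, going by these compounds, is whether the shift is specific to the methyl ester. The matching carboxylic acid, an ethyl ester or a longer chain ending in the ester would test this.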